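This account rests on a few compounds, and the source may have more. Where it says the series, first, only, none or still open, it means among the compounds named here.

Measured so far:
Compound 1 `CC(=O)Nc1c(C(O)(C(F)(F)F)C(F)(F)F)ccc2ccccc12` gives 87% in a functional assay (Sus scrofa) with sulfonylurea receptors; K-ATP channels (Homo sapiens) as the target; a higher number here means a larger maximal response, a lower number a smaller maximal response.
Compound 2 `CCCC(=O)Nc1c(C(O)(C(F)(F)F)C(F)(F)F)ccc2ccccc12` gives 92% in this assay.
Compound 3 `CC(C)=CC(=O)Nc1c(C(O)(C(F)(F)F)C(F)(F)F)ccc2ccccc12` gives 96% in this assay.

Compound 2 stands second highest of the three numbers, with compound 3 nearest, a number 4 percentage points higher from compound 2 to compound 3 (within the scatter), and compound 1 furthest, a number 5 percentage points higher from compound 1 to compound 2 (within the scatter); all three steps, including a number 9 percentage points higher from compound 1 to compound 3 (within the scatter), lie within the scatter. Compound 4 `O=C(Nc1c(C(O)(C(F)(F)F)C(F)(F)F)ccc2ccccc12)c1ccc(Cl)cc1` differs from compound 2 by 4-chlorophenyl in place of propyl on a carbonyl carbon. The measured steps that bear on it are those at the carbonyl carbon, a number 5 percentage points higher from compound 1 to compound 2 (within the scatter) and a number 4 percentage points higher from compound 2 to compound 3 (within the scatter), both within the scatter. No aryl group at that place has been measured, so the step is uncertain, but on these data no change beyond the scatter is expected: a number 2 percentage points lower from compound 2 to compound 4 (within the scatter). Compound 4 is therefore estimated at 90%, between 72% and 100%.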

Compound 4, largest response reached (reported as efficacy), in percent of the reference or control that the assay uses: 99%
For compound 4 the middle estimate is 9 percentage points below the measured one, and the stated range covers the measured number.
By their numbers in this assay, from the lowest: compounds 1, 2, 3 and 4 (each within the scatter of the next, the first and the last beyond it).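

In this assay, the carbonyl carbon accepts an aromatic ring in place of an open chain without a loss of response: 4-chlorophenyl stands level with propyl (a number 7 percentage points higher from compound 2 to compound 4 (within the scatter)) and with 2-methylprop-1-en-1-yl (a number 3 percentage points higher from compound 3 to compound 4 (within the scatter)). Only against methyl does this change give a step beyond the scatter, and a modest one (a number 12 percentage points higher from compound 1 to compound 4 (beyond the scatter)). No evidence shown explains these results. The compounds shown leave open what the chlorine contributes, which plain phenyl would test, and whether a pyridine ring or a 4-methoxyphenyl group at this place would hold the response.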